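A few compounds are considered here, and "the series" means these few. Any claim that something is new, unique, unknown or untested is made for them only; others in the source may bear on it.

Measured compounds:
- compound 1 `COc1ccc(C(C)NC(=O)/N=C(\N)NCCCc2sc(N)nc2C)cc1`: 37.2 nM
- compound 2 `CCCNC(=O)/N=C(\N)NCCCc1sc(N)nc1C`: 105 nM
- compound 3 `N/C(=N\C(=O)NCc1ccccc1)NC1CCc2nc(N)sc2C1`: 513 nM

All three were tested in an assay on membranes from Sf9 cells for displacement of a labelled ligand from histamine H2 receptor (Homo sapiens), read by scintillation counting, with a stated time of 60 min; a higher number here means a weaker inhibitor, a lower number a stronger inhibitor. Among them, compound 1 stands at the lowest number; compound 2 lies at a higher number, beyond the scatter, and compound 3 lies further still, also beyond the scatter. Compound 1 is therefore the strongest inhibitor of the three in this assay.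

The next compound, compound 4 `Cc1nc(N)sc1CCCN/C(N)=N/C(=O)NC(C)c1ccc(Br)cc1`, has not yet been tested in this assay. It is derived from compound 1 by a single change: bromo in place of methoxy on an aromatic carbon. Going by the values given here, no pair among the tested compounds differs by this change alone, so no measured step tells what it does here. With the shared core, the acylguanidine and the substituted phenylethyl group otherwise unchanged, the expectation rests on compound 1 alone and on its value of 37.2 nM. Without a reference step, the change is expected to leave the number close to where compound 1 stands, with no clear direction beyond the scatter. For compound 4 the estimated step of a 1.1-fold higher number from compound 1 to compound 4 (0.03 log units; within the scatter) is thus small. Compound 4 is expected to give about 40 nM in this assay, within a range from 12 nM to 130 nM.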

Compound 4, inhibition constant: 30.2 nM
For compound 4 the middle estimate is 1.3-fold (0.12 log units) above the measured one; measured number inside the range.
By their numbers in this assay, from the lowest: compounds 4 and 1 (each within the scatter of the next); then compound 2; then compound 3.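

In this assay, going by these compounds alone, putting bromo in place of methoxy on the aromatic ring gives a 1.2-fold lower number from compound 1 to compound 4 (0.09 log units; within the scatter), the first measured step at this position, para to a large group. The swap removes two heavy atoms and the one hydrogen-bond acceptor counted on the methoxy, brings in a single bromine with no acceptor, and still leaves compound 4 level with compound 1, so in this pair the acceptor on the methoxy is not required to keep the number at this level. Nothing available explains why the two groups give matching numbers.

The compounds shown carry only methoxy and bromo at this position, so it remains open whether a plain hydrogen, an amine, a hydroxyl or a carboxylic acid there would also hold the number or move it beyond the scatter. As far as these compounds go, it is also open whether the same swap would behave alike with a different chain, such as the propyl group of compound 2 extended by a phenyl ring without the branching methyl.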